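The source may hold more compounds than are shown below. What is called first, only, known or untested is meant among the compounds shown, and "the series" means these compounds.

Measured so far in a physicochemical assay for solubility, read by HPLC, in phosphate buffer, at pH 6.5; a higher number here means a more soluble compound, a lower number a less soluble compound:
- compound 1 `COC(=O)C1=C(CN2CC3CC2CO3)NC(c2nccs2)=NC1(C)c1ccc(F)cc1` gives 564 ug/mL
- compound 2 `COC(=O)C1=C(Cn2ccnc2)NC(c2nccs2)=NC1(C)c1ccc(F)cc1` gives 338 ug/mL

Within the data shown here, of only two numbers, compound 2 at 338 ug/mL lies within the scatter of compound 1 at 564 ug/mL and so stands level with it for now. Next in line is compound 3 `COC(=O)C1=C(COC(C(=O)O)C(F)(F)F)NC(c2nccs2)=NC1(C)c1ccc(F)cc1`, which keeps the shared core and differs from compound 2 in one place (a group of 9 heavy atoms (3 carbon, 3 oxygen, 3 fluorine; no ring) in place of a group of 5 heavy atoms (3 carbon, 2 nitrogen; one five-membered aromatic ring with 2 hetero atoms), on a saturated chain carbon bound to a double-bonded ring carbon).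

Among the measured compounds shown here, one measured step bears on this, at the same carbon. That step is a 1.7-fold lower number from compound 1 to compound 2 (0.22 log units; within the scatter) and it exchanged one ring-bearing group for another. For the measured compounds named here, no measured compound carries a group without a ring at this place, so the data offer no direct guide, and the 1H-imidazol-1-yl group leaves for a group of a different kind. A moderate rise in this assay is expected, with low confidence. The expected size is a 2.4-fold higher number from compound 2 to compound 3 (0.37 log units; beyond the scatter) and the range is kept wide. For compound 3 the estimated value is 800 ug/mL with an expected range from 250 ug/mL to 2000 ug/mL in this read-out.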

Compound 3, solubility: > 649 ug/mL
Compound 3: a limit, no number; the forecaster's own chance of this, stated with the estimate: 20%; the middle value does not contradict the limit.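

Compound 3 gives a limit in this assay and not a number: the limit of > 649 ug/mL in this assay, at which 1 of the 3 values shown sits.

Read as floors, the two steps stand as an at least 1.9-fold higher number from compound 2 to compound 3 (0.28 log units; that floor lies within the scatter) and an at least 1.1-fold higher number from compound 1 to compound 3 (0.06 log units; that floor lies within the scatter); both floors lie within the scatter, so neither step yet separates compound 3 from the two ring-bearing compounds, and its true distance from them stays unknown. What is new for the saturated chain carbon bound to a double-bonded ring carbon is that a group with no ring, carrying one hydrogen-bond donor where the 1H-imidazol-1-yl group carries none, is compatible with a reading at this level, so a ring at this place is not required for it.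

From the compounds shown here alone, how far compound 3 lies past its limit stays open, and so does which part of the entering group counts, as the trifluoromethyl and carboxylic acid parts enter together. A simple amine chain at this carbon, or the same chain with a methyl in place of the trifluoromethyl, would begin to pull these parts apart.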